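A few compounds are considered here, and "the series" means these few. Any claim that something is new, unique, unknown or untested is made for them only; others in the source may bear on it.

Compound 1 `COc1ccc(-c2nc3cc(C(F)(F)F)ccc3[nH]2)cc1`: in an ADME assay on BHK cells (Mesocricetus auratus) for cytotoxicity, read by MTT assay, with a stated time of 96 h (a higher number here means that more compound is tolerated, a lower number that less compound is tolerated), compound 1 gives > 100000 nM, which is a limit of the assay.
Compound 2 `CCN(CC)CC(=O)Nc1ccc(-c2nc3cc(C(F)(F)F)ccc3[nH]2)cc1`: in this assay compound 2 gives 23000 nM.

Going by the values given here, compound 2 thus holds the only measured number in this set, the other value shown being a limit (the limit of > 100000 nM in this assay, at which 1 of the 2 values shown sits). Among the compounds with values here, the one measured step, an at least 4.3-fold lower number from compound 1 to compound 2 (0.63 log units; beyond the scatter), swaps one group on an aromatic carbon for another and leaves the amine untouched. Compound 3 `O=C(CN1CCCCC1)Nc1ccc(-c2nc3cc(C(F)(F)F)ccc3[nH]2)cc1` differs from compound 2 by piperidin-1-yl in place of diethylamino on a saturated chain carbon bound to a carbonyl carbon. Within the data shown here, no measured step bears on this exchange of one amine for another, since the only step changed a different part of the molecule. For compound 3 the expected step in this assay is therefore no change at the digits printed from compound 2 to compound 3 (within the scatter), that is, none beyond the scatter. Compound 3 is expected to give about 23000 nM in this assay, with a likely range from 10000 nM to 55000 nM.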

Compound 3, half-maximal cytotoxic concentration: 12000 nM
Compound 3: the middle estimate sits 1.9-fold (0.28 log units) above what was measured; measured number inside the range.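

In a 1.9-fold lower number from compound 2 to compound 3 (0.28 log units; within the scatter), this assay reads the exchange of diethylamino for piperidin-1-yl on a saturated chain carbon bound to a carbonyl carbon. Going by these compounds alone, the only earlier step changed a group on an aromatic carbon, so this is the first look at the amine itself: here, replacing an amine without a ring by one carrying a six-membered non-aromatic ring leaves the difference inside the usual variation between repeated measurements. Nothing in the data at hand explains this small difference.

Still open, on these data alone, is how this place responds to other groups, such as the smaller ring of pyrrolidin-1-yl, morpholin-4-yl with its ring oxygen, or a carboxylic acid in place of the amine. Also open, as far as these compounds go, is whether a longer chain between the carbonyl and the amine gives a similar number.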